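Exchanging the cyclopropyl group for a hydroxypropyl chain

A few compounds are considered here, and "the series" means these few. Any claim that something is new, unique, unknown or untested is made for them only; others in the source may bear on it.

Measured so far:
Compound 1, `Fc1ccccc1Cn1nnc2c(NC3CC3)nc(-c3ccccc3)nc21`: 15 nM
Compound 2, `FC(F)(F)c1ccccc1Cn1nnc2c(NC3CC3)nc(-c3ccccc3)nc21`: 7.8 nM

Both numbers come from an assay on Cerebral cortex for displacement of a labelled ligand from adenosine receptor A1 (Bos taurus); a higher number here means a weaker inhibitor, a lower number a stronger inhibitor. Among the two, compound 1 stands with the highest number, and compound 2 is its only neighbour: a 1.9-fold lower number from compound 1 to compound 2 (0.28 log units; within the scatter). The two compounds therefore cannot be told apart by this assay.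

Compound 3 `OCCCNc1nc(-c2ccccc2)nc2c1nnn2Cc1ccccc1F` has not yet been measured. It differs from compound 1 in one place: 3-hydroxypropyl in place of cyclopropyl on a nitrogen on an aromatic ring. For the measured compounds named here, the single measured step, from compound 1 to compound 2, concerns an exchange of fluoro for trifluoromethyl on an aromatic carbon, a different part of the molecule, so it gives no guidance on the present change. Without a measured step that bears on it, the expectation for compound 3 rests on the change alone: a three-membered ring leaves and an open chain carrying a hydrogen-bond donor and acceptor enters, and a step toward a higher number, possibly beyond the scatter, is expected: a 3.0-fold higher number from compound 1 to compound 3 (0.48 log units; beyond the scatter). Compound 3 is accordingly estimated at 45 nM, within a range from 10 nM to 200 nM.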

Compound 3, inhibition constant: 3.7 nM
Estimate against measurement, compound 3: 12-fold (1.09 log units) above, outside the stated range (below it).
By their numbers in this assay, from the lowest: compound 3; then compounds 2 and 1 (each within the scatter of the next).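

This position, a nitrogen on an aromatic ring, does not depend on the three-membered ring: in this assay, exchanging cyclopropyl for 3-hydroxypropyl gives a 4.1-fold lower number from compound 1 to compound 3 (0.61 log units; beyond the scatter) and so yields a stronger inhibitor, although the step is modest. The earlier pair varied only the group on an aromatic carbon and stayed within the scatter, which makes this the only step shown that moves the number beyond the scatter. Nothing available explains the gain or shows which part of the new chain matters.

The exchange removes the ring and brings in an open chain and a hydroxyl group in a single step, so the compounds shown cannot separate these contributions; a plain propyl group would show what the open chain does without the hydroxyl, while 3-methoxypropyl would replace the hydroxyl hydrogen with a methyl group. Also open, from the compounds shown here alone, are whether a shorter 2-hydroxyethyl or a longer 4-hydroxybutyl chain would keep the lower number, and whether 3-hydroxypropyl would have the same effect alongside the trifluoromethyl group of compound 2.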